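A few compounds are considered here, and "the series" means these few. Any claim that something is new, unique, unknown or untested is made for them only; others in the source may bear on it.

Measured compounds:
compound 1 `COc1cc2c(Oc3c(F)cc(NC(=O)NN4C(=O)CSC4c4c(F)cccc4F)cc3F)ccnc2cc1OCCCN1CCCC1` — 230 nM
compound 2 `COc1cc2c(Oc3c(F)cc(NC(=O)NN4C(=O)C(C)SC4c4c(F)cccc4F)cc3F)ccnc2cc1OCCCN1CCCC1` — 670 nM

Among the measured compounds shown here, in a functional assay on HT-29 cells (Homo sapiens) for antiproliferative activity, read by MTT assay, with a stated time of 72 h (on this read-out higher numbers stand for weaker inhibition and lower numbers for stronger inhibition), compound 1 gives the lower of these two numbers, and the only measured step, a 2.9-fold higher number from compound 1 to compound 2 (0.46 log units; beyond the scatter), concerns a methyl on a saturated ring carbon. Compound 3 `COc1cc2c(Oc3c(F)cc(NC(=O)NN4C(=O)CSC4c4c(F)cccc4F)cc3F)ccnc2cc1OCCCN1CCN(C)CC1` differs from compound 1 elsewhere: 4-methylpiperazin-1-yl in place of pyrrolidin-1-yl on a saturated chain carbon, three bonds along the chain from an oxygen on an aromatic ring. For the measured compounds named here, no measured step touches this end of the chain, so the expectation rests on the unchanged remainder of the molecule alone, and a step within the scatter is expected, a 1.3-fold higher number from compound 1 to compound 3 (0.12 log units; within the scatter). Compound 3 is therefore estimated at 300 nM, with a range from 110 nM to 850 nM.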

Compound 3, half-maximal inhibitory concentration: 150 nM
Compound 3: middle estimate off by 2.0-fold (0.30 log units), on the high side; low and high end bracket the measured number.
By their numbers in this assay, from the lowest: compounds 3 and 1 (each within the scatter of the next); then compound 2.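

In this assay, exchanging the five-membered pyrrolidin-1-yl ring for the six-membered 4-methylpiperazin-1-yl ring, with its second ring nitrogen, gives a 1.5-fold lower number from compound 1 to compound 3 (0.19 log units; within the scatter) at the end of the chain. At this position, then, these two rings cannot be told apart by this read-out, even though they differ in size and hetero atoms. No available measurement bears on why they read alike. The compounds shown leave open how a morpholin-4-yl ring, a dimethylamino group or a longer chain would read here. They also leave open whether 4-methylpiperazin-1-yl would read the same alongside the added methyl of compound 2.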